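Chloro on the benzylsulfanyl ring: meta measured, ortho expected

The source may report more compounds than this note shows. Statements on the series, on what has been measured and on what is new or still open speak of the compounds shown alone.

Three compounds of this series have been run in a functional assay on the whole organism (artery, strain albino) with Rattus norvegicus as the target, with a stated time of 720 min, at a dose of 10 mg/kg by the oral route; a higher number here means more inhibition at the dose given (going by the name of the read-out), a lower number less inhibition. Compound 1 `CC1=C(C(=O)Nc2ccc(F)cc2)C(c2ccc([N+](=O)[O-])cc2)N=C(SCc2ccccc2)N1` gives 27.3% in this assay. Compound 2 `CC1=C(C(=O)Nc2ccc(F)cc2)C(c2ccc([N+](=O)[O-])cc2)N=C(SCc2cccc(Cl)c2)N1` differs from compound 1 by chloro in place of hydrogen on an aromatic carbon. In this assay, for the measured compounds named here, compound 2 gives 12.9%; the step of a number 14.4 percentage points lower from compound 1 to compound 2 (beyond the scatter) is the only single-point change measured so far. Compound 3 `CC1=C(C(=O)Nc2ccc([N+](=O)[O-])cc2)C(c2cccc([N+](=O)[O-])c2)N=C(SCc2ccccc2)N1` gives 17.5% in this assay; the difference between the core of compound 3 and the core of compound 1 is not broken down here, and the values of compound 3 and compound 2, as of compound 3 and compound 1, lie within the scatter of each other.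

Compound 4 `CC1=C(C(=O)Nc2ccc([N+](=O)[O-])cc2)C(c2cccc([N+](=O)[O-])c2)N=C(SCc2ccccc2Cl)N1` is not yet measured. It differs from compound 3 by chloro in place of hydrogen on an aromatic carbon. Going by the values given here, this is the same kind of change as the one from compound 1 to compound 2, not the same: there the chlorine enters meta to a large group, here ortho to a large group. Among the compounds with values here, since the meta case is the only measured precedent, the expectation for compound 4 leans on the value of compound 3, 17.5%, and on the step of a number 14.4 percentage points lower from compound 1 to compound 2 (beyond the scatter), with wide bounds for the changed place. Compound 4 is expected to give 9% in this assay, between 0% and 22%. The expected step from compound 3 is a number 8.5 percentage points lower from compound 3 to compound 4 (within the scatter).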

Compound 4, a percentage reported as inhibition, in the whole organism at one dose (the size of the read-out at that dose, not a potency): 11.3%
For compound 4 the middle estimate is 2.3 percentage points below the measured one; the range from low to high includes it.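

In this assay, chloro in place of hydrogen on the ring of the benzylsulfanyl group can now be read on two cores, and the new reading is a number 6.2 percentage points lower from compound 3 to compound 4 (within the scatter), a step that cannot be told from no change on its own. Set beside the earlier step, the new one does not separate from it, which gives no sign of a core dependence in this small set: the same change on two cores in this assay, a number 14.4 percentage points lower (beyond the scatter) from compound 1 to compound 2 and a number 6.2 percentage points lower (within the scatter) from compound 3 to compound 4, 8.2 percentage points apart, within the scatter of two such steps. For the compounds shown here, this does not show that the change carries over unchanged, since there are only two steps, the chlorine sits at a different place on the ring in each, the influence of place and core cannot be pulled apart, and each reading comes from a single oral dose.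

Open, as far as these compounds go, is how (2-chlorobenzyl)sulfanyl reads on the core of compound 1, the comparison that would hold the core fixed and vary only the place of the chlorine. Also open, from the compounds shown here alone, is how this position responds to anything other than hydrogen and chloro, such as fluoro, methoxy or a carboxylic acid on the ring, or a longer alkyl chain or an amine-bearing chain in place of the benzyl group on sulfur.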